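Dropping one methoxy group from compound 1

The source may report more compounds than this note shows. Statements on the series, on what has been measured and on what is new or still open speak of the compounds shown alone.

Measured so far:
compound 1 `COc1cc(/C=N/NC(=O)CCCc2nc3ccccc3c(=O)[nH]2)cc(O)c1O` gives 277000000 nM
compound 2 `COc1cc(/C=N/NC(=O)CCc2nc3ccccc3c(=O)[nH]2)cc(OC)c1OC` gives 682000000 nM

Both were tested in a functional assay on cells (Erythrocyte, Homo sapiens) for inhibition, read by spectrophotometry and hemolysis, with a stated time of 10 min; on this read-out higher numbers stand for weaker inhibition and lower numbers for stronger inhibition. Compound 1 has the lowest of the two numbers; compound 2 sits higher, a gap beyond the usual scatter. Compound 3 `O=C(CCCc1nc2ccccc2c(=O)[nH]1)N/N=C/c1ccc(O)c(O)c1` is not yet measured. Against compound 1 the change is hydrogen in place of methoxy on an aromatic carbon. Among the measured compounds shown here, no step between measured compounds is known, so a small step is expected: a 1.1-fold lower number from compound 1 to compound 3 (0.04 log units; within the scatter), within the scatter and in no firm direction. Compound 3 is estimated at 250000000 nM, with a range from 90000000 nM to 700000000 nM.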

Compound 3, half-maximal inhibitory concentration: 300000000 nM
The estimate for compound 3 lay 1.2-fold (0.08 log units) below the measured number; the measured number falls inside the stated range.
By their numbers in this assay, from the lowest: compounds 1 and 3 (each within the scatter of the next); then compound 2.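

In this assay, hydrogen in place of methoxy on this aromatic carbon, ortho to a hydroxy group, gives a 1.1-fold higher number from compound 1 to compound 3 (0.03 log units; within the scatter), so the two compounds cannot be told apart on this read-out. At this position, then, the methoxy group can be removed without a measurable loss of inhibition. Nothing available explains this outcome. Still open, as far as these compounds go, is whether a different group on this carbon, such as an amine or a carboxylic acid, would give a number beyond the scatter. From the compounds shown here alone, whether the same holds with a longer chain on the shared core also remains open.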